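The compounds below may be only part of what the source reports. "The series", "measured", "known", "first", "only" and "open" are said of these compounds alone.

Measured in a physicochemical assay for solubility, using the shake flask method, in phosphate buffer, measured as kinetic solubility, with a stated time of 20 h, at pH 6.5; on this read-out lower numbers stand for lower solubility and higher numbers for higher solubility:
- compound 1 `COc1cccnc1Nc1cc2[nH]c(-c3cccc(C(F)(F)F)c3)nc2cn1`: < 5000 nM
- compound 2 `Fc1ccc(-c2nc3cnc(Nc4ccc(C(F)(F)F)cn4)cc3[nH]2)cc1F`: < 5000 nM
- compound 3 `Fc1ccc(Nc2cc3[nH]c(-c4ccc(F)c(F)c4)nc3cn2)nc1`: < 5000 nM

All three entries are limits of the assay and not numbers.

Compound 2 therefore has no numerical standing in this assay, only the limit < 5000 nM.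

Compound 4 `FC(F)(F)c1ccc(Nc2cc3[nH]c(C4CC4)nc3cn2)nc1` differs from compound 2 in one place: cyclopropyl in place of 3,4-difluorophenyl on an aromatic carbon. A one six-membered aromatic ring of carbon only leaves, and a three-membered non-aromatic ring of carbon only enters, on an aromatic carbon of a five-membered aromatic ring with 2 nitrogen.

For the measured compounds named here, only one measured step is available: a step that the two limits leave unreadable from compound 2 to compound 3. It concerns fluoro in place of trifluoromethyl, a different change at a different place, and it has no readable size. Going by the values given here, no measured step covers the replacement of 3,4-difluorophenyl by cyclopropyl, so neither a size nor a direction can be carried over. No step beyond the scatter is expected on these data, although a reported number for compound 4 remains possible.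

Compound 4 is therefore expected to stay close to the limit of < 5000 nM in this assay, at which 3 of the 3 values shown sit. For compound 4 the estimated solubility is 4000 nM, with an expected range of 1000 nM to 15000 nM. This estimate means an expected step that the limit leaves unreadable from compound 2 to compound 4.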

Compound 4, solubility: < 5000 nM
Compound 4 gave a limit, no number; the forecaster's own chance of this, stated with the estimate: 60%; the middle value does not contradict the limit.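

In this assay compound 4 gives < 5000 nM, a limit and not a number. For the compounds shown here, compound 2 also stands at a limit, so no step between compound 2 and compound 4 can be read. The compounds shown leave open the actual solubility of each compound, and whether cyclopropyl in place of 3,4-difluorophenyl changes it at all, with everything resting on one entry: the limit of < 5000 nM in this assay, at which 4 of the 4 values shown sit.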